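The compounds below may be only part of what the source reports. "The series", "measured", "known", "first", "only" and "open" are said of these compounds alone.

Working notes on the series. Two compounds have half-life numbers in an ADME assay on microsomes from liver (Homo sapiens) for metabolic stability, read by LC-MS, using NADPH, tested at 5 uM; on this read-out higher numbers stand for a longer-lived compound and lower numbers for a shorter-lived compound. Compound 1 `Cc1cccc(CSc2cc(Cl)c(C)cc2S(=O)(=O)/N=C(\N)n2nccc2-c2ccccc2)c1` gives in this assay 0.232 h. Compound 2 `Cc1cc(-c2ccccc2)n(/C(N)=N/S(=O)(=O)c2cc(C)c(Cl)cc2SCc2cccc3ccccc23)n1` gives in this assay 0.256 h, the higher of the two numbers, with compound 1 nearest; the gap between the two lies within the usual scatter, so neither can be called longer-lived than the other.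

Compound 3 `Cc1ccc(CSc2cc(Cl)c(C)cc2S(=O)(=O)/N=C(\N)n2nc(C)cc2-c2ccccc2)cc1` has not yet been run in this assay. Compared with compound 2 it carries 4-methylphenyl in place of naphthalen-1-yl on a saturated chain carbon bound to a sulfur, the rest of the structure being unchanged. Among the compounds with values here, no measured pair in the set shows this change, so no step size can be read off. Within the data shown here, compound 1 and compound 2 show that a change in the benzylic substituent together with the methyl on the core leaves the number within the scatter, which is the only guide available. The step from compound 2 to compound 3 is expected to be a 1.1-fold higher number from compound 2 to compound 3 (0.04 log units; within the scatter), small and in no clear direction beyond the scatter. In this assay compound 3 is therefore estimated at 0.28 h, with a range from 0.15 h to 0.5 h.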

Compound 3, half-life: 0.176 h
The estimate for compound 3 lay 1.6-fold (0.20 log units) above the measured number; measured number inside the range.
By their numbers in this assay, from the lowest: compounds 3, 1 and 2 (each within the scatter of the next).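

In this assay, this position, a saturated chain carbon bound to a sulfur, now has its first readable step: a 1.5-fold lower number from compound 2 to compound 3 (0.16 log units; within the scatter). Exchanging naphthalen-1-yl, with two six-membered aromatic rings of carbon only, for 4-methylphenyl, with one such ring, therefore gives half-lives that cannot be told apart, so the second ring makes no measurable difference in this pair. No measurement bears on what lies behind this result.

As far as these compounds go, both groups at this position are all-carbon aromatic groups, so it remains open whether an amine or a carboxylic acid in the same place would shift the half-life beyond the scatter. Also open, from the compounds shown here alone, is whether an unsubstituted phenyl would read differently from 4-methylphenyl.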